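This account rests on a few compounds, and the source may have more. Where it says the series, first, only, none or still open, it means among the compounds named here.

Measured in a functional assay on HL-60 cells (Homo sapiens) for cytotoxicity, read by WST assay, with a stated time of 48 h; on this read-out higher numbers stand for weaker inhibition and lower numbers for stronger inhibition:
- compound 1 `COC[C@H](C)[C@@H](C)C(c1ccc(O)c(OC)c1)c1ccc(O)c(OC)c1`: 68000 nM
- compound 2 `COc1cc(C(c2ccc(O)c(OC)c2)[C@H](CF)C(C)C)ccc1O`: 19000 nM
- compound 3 `CCCCCCCC[C@H](C(C)C)C(c1ccc(O)c(OC)c1)c1ccc(O)c(OC)c1`: 3700 nM

Compound 3 has the lowest number of the three, which makes it the strongest inhibitor so far. Compound 4 `COc1cc(C(c2ccc(O)c(OC)c2)[C@H](CC(C)C)C(C)C)ccc1O` alters it as follows: isopropyl in place of heptyl on a saturated chain carbon, three bonds along the chain from two aromatic carbons. In words, isopropyl stands in place of heptyl on a saturated chain carbon, three bonds along the chain from two aromatic carbons.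

The best guide is the modest step at this same place, a 5.1-fold lower number from compound 2 to compound 3 (0.71 log units; beyond the scatter), where heptyl replaced fluoro. The other step, a 3.6-fold lower number from compound 1 to compound 2 (0.55 log units; beyond the scatter), is also modest. Removing the heptyl is expected to reverse part of the gain, so the expected change is a 2.4-fold higher number from compound 3 to compound 4 (0.39 log units; beyond the scatter). For compound 4 the estimate is 9000 nM, with an expected range of 4000 nM to 20000 nM.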

Compound 4, half-maximal inhibitory concentration: 9600 nM
Compound 4: middle estimate off by 1.1-fold (0.03 log units), on the low side; low and high end bracket the measured number.
By their numbers in this assay, from the lowest: compound 3; then compounds 4 and 2 (each within the scatter of the next); then compound 1.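

In this assay, isopropyl in place of heptyl gives a step beyond the scatter (a 2.6-fold higher number from compound 3 to compound 4 (0.41 log units; beyond the scatter)), so at this place the heptyl group is linked to the lower number. Isopropyl and fluoro, however, remain within the scatter of each other (a 2.0-fold lower number from compound 2 to compound 4 (0.30 log units; within the scatter)), while compound 4 still stands clear of compound 1 (a 7.1-fold lower number from compound 1 to compound 4 (0.85 log units; beyond the scatter)). No supporting measurement explains these differences. Open, going by these compounds, is where a pentyl group or a longer chain such as decyl would fall, and how an amine or a carboxylic acid at this place would compare.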